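Swapping Phenyl for Isopropyl on a Kinase Inhibitor Core

The compounds below may be only part of what the source reports. "The series", "measured", "known", "first", "only" and "open" are said of these compounds alone.

Compound 1 `CC(C)n1nc(-c2cc(-c3ccccc3)on2)c2c(N)ncnc21` is the reference point. In an assay on BaF3 cells for inhibition of proto-oncogene tyrosine-protein kinase receptor Ret (Homo sapiens), read by MTT assay, with a stated time of 48 h (on this read-out lower numbers stand for stronger inhibition of growth and higher numbers for weaker inhibition of growth), compound 1 gives 3460 nM, the lowest of the two numbers obtained so far. Compound 3 `CC(C)n1nc(-c2cc(C3CCCCC3)on2)c2c(N)ncnc21` carries cyclohexyl in place of phenyl on an aromatic carbon, and in this assay compound 3 gives 9500 nM. That change amounts to a 2.7-fold higher number from compound 1 to compound 3 (0.44 log units; beyond the scatter), so the aromatic ring is the better of the two groups on this position among the compounds measured. For compound 2 `CC(C)n1nc(/C=N/O)c2c(N)ncnc21` this assay reports > 10000 nM, which is a limit of the assay rather than a number; it stands at the limit of > 10000 nM in this assay, at which 1 of the 3 values shown sits.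

Compound 4 `CC(C)c1cc(-c2nn(C(C)C)c3ncnc(N)c23)no1` has not yet been measured. It differs from compound 1 in one place: isopropyl in place of phenyl on an aromatic carbon. Going by the values given here, the only measured step that bears on this change is the one from phenyl to cyclohexyl, which raised the number beyond the scatter. Both changes remove the phenyl ring in favor of a carbon group that carries no aromatic ring, so a step in the same weakening direction is expected, estimated as a 2.3-fold higher number from compound 1 to compound 4 (0.36 log units; beyond the scatter). Compound 4 is therefore expected to give about 8000 nM in this assay, with a likely range from 3000 nM to 20000 nM.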

Compound 4, concentration for 50% growth inhibition: 2400 nM
Estimate against measurement, compound 4: 3.3-fold (0.52 log units) above, and the stated range ends above it.
By their numbers in this assay, from the lowest: compounds 4 and 1 (each within the scatter of the next); then compound 3. At a limit, above all of these: compound 2.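

In this assay the change to isopropyl gives a 1.4-fold lower number from compound 1 to compound 4 (0.16 log units; within the scatter) and so leaves the two compounds indistinguishable, which means that an aromatic ring on this carbon, next to the ring oxygen, is not required to keep this level of growth inhibition. The earlier comparison of phenyl with cyclohexyl suggested that the aromatic ring was the better choice, but a 4.0-fold lower number from compound 3 to compound 4 (0.60 log units; beyond the scatter) shows that the weaker result of compound 3 does not extend to every group without an aromatic ring; among these three groups, cyclohexyl is the one that stands apart. Nothing measured here explains why cyclohexyl and isopropyl part ways on this position.

On these data alone, whether a group smaller than isopropyl, such as methyl, would keep the same level of inhibition remains open, as does the effect of a group carrying an amine or a carboxylic acid. As far as these compounds go, it is also open whether a longer open chain, such as n-butyl, would stay level with compound 4 or move toward compound 3.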